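The source may hold more compounds than are shown below. What is called first, only, known or untested is meant among the compounds shown, and "the series" means these compounds.

Measured in an ADME assay on KB cells (Homo sapiens) for cytotoxicity; on this read-out lower numbers stand for an effect already at smaller amounts and higher numbers for an effect only at larger amounts of compound:
- compound 1 `COC(=O)N1[C@@H]2C=C[C@@](OC)(C(=O)c3c2cc(OC)c(OC)c3OCc2ccccc2F)N1C(=O)OC`: 137 ug/mL
- compound 2 `CCOC(=O)N1[C@@H]2C=C[C@@](OC)(C(=O)c3c2cc(OC)c(OC)c3OCc2ccc(Cl)cc2)N1C(=O)OCC`: 99.9 ug/mL
- compound 3 `COc1cc2c(c(OCc3ccc(F)cc3)c1OC)C(=O)[C@]1(OC)C=C[C@H]2N(C(=O)OCC(C)C)N1C(=O)OCC(C)C`: > 300 ug/mL

Compound 1 with 137 ug/mL and compound 2 with 99.9 ug/mL lie within the usual scatter of each other. Compound 3 gives > 300 ug/mL, and this reading is a limit and not a number. Of the three readings, it is the only one at the limit of > 300 ug/mL in this assay, at which 1 of the 3 values shown sits.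

The next compound is compound 4 `CCCOc1c(OC)c(OC)cc2c1C(=O)[C@]1(OC)C=C[C@H]2N(C(=O)OCC(C)C)N1C(=O)OCC(C)C`. It differs from compound 3 in one place, with ethyl in place of 4-fluorophenyl on a saturated chain carbon bound to an oxygen on an aromatic ring. Cut one bond further out, the same change reads (4-fluorobenzyl)oxy to propoxy.

Among the measured compounds shown here, no pair of measured compounds shows this change alone, so its size in this assay cannot be read from the data. The closest reference is compound 3 with > 300 ug/mL, again a limit, since it shares everything with compound 4 apart from this change. No step beyond the scatter is expected, and the expected move is an at least 1.0-fold lower number from compound 3 to compound 4 (0.02 log units; that floor lies within the scatter). A result reported only as a limit would not be surprising. For compound 4 the estimated value is 280 ug/mL, with an expected range from 110 ug/mL to 600 ug/mL.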

Compound 4, concentration for half-maximal effect: 299 ug/mL
For compound 4 the middle estimate is 1.1-fold (0.03 log units) below the measured one; the measured number falls inside the stated range.
By their numbers in this assay, from the lowest: compounds 2 and 1 (each within the scatter of the next); then compound 4. At a limit, above all of these: compound 3.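

In this assay, the change from (4-fluorobenzyl)oxy to propoxy gives a number no higher from compound 3 to compound 4 (the limit leaves the size open). Among the compounds shown here, this is the first comparison that isolates this place, on a saturated chain carbon bound to an oxygen on an aromatic ring, and it shows that the aromatic ring of the 4-fluorobenzyl group can give way to a plain propyl while compound 4 still gives 299 ug/mL in this assay. Compound 3 gives > 300 ug/mL, which is a limit and not a number, and it remains the only reading of that kind: the limit of > 300 ug/mL in this assay, at which 1 of the 4 values shown sits.

Going by these compounds, the size of the step cannot be read, so how much the ring contributes at this place stays open, and compounds 1 and 2 differ from compound 4 in more than one place and offer no comparison for the propoxy group. Also open, on these data alone, is how this assay responds when this place carries a longer chain, an amine or a carboxylic acid, and whether the reading of compound 4 holds with other carbamate groups on the shared core.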